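The source may hold more compounds than are shown below. What is called first, only, known or untested is meant among the compounds shown, and "the series" means these compounds.

Working notes on the series. Among the measured compounds shown here, compound 2 `ClCc1ccccc1Cn1cnc2c(Cl)nc(Cl)nc21` carries the lowest of the two numbers so far: in a functional assay on KM12 cells (Homo sapiens) for cytotoxicity, read by sulforhodamine B assay, with a stated time of 48 h (a lower number here means a stronger inhibitor of growth, a higher number a weaker inhibitor of growth), compound 2 gives 1470 nM. Its nearest neighbour is compound 1 `ClCc1ccc(Cn2cnc3c(Cl)ncnc32)cc1`, which in this assay gives 2140 nM; the two values lie within the scatter of each other, so no order between them is claimed. Compound 3 `ClCc1ccccc1Cn1cnc2c(Cl)ncnc21` has not yet been measured. Relative to compound 2 it shows (hydrogen in place of chloro on an aromatic carbon). For the measured compounds named here, no pair of measured compounds isolates this change, so its effect cannot be read from the numbers at hand; compound 1 also shares the single ring chloro of compound 3 but differs in where the chloromethyl sits, and no step for that pair is given. The expectation for compound 3 is therefore a step of at most modest size, in no firm direction, a 1.4-fold higher number from compound 2 to compound 3 (0.13 log units; within the scatter). Compound 3 is estimated at 2000 nM, with a range from 800 nM to 5000 nM.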

Compound 3, concentration for 50% growth inhibition: 16600 nM
Estimate against measurement, compound 3: 8.3-fold (0.92 log units) below, and the stated range ends below it.
By their numbers in this assay, from the lowest: compounds 2 and 1 (each within the scatter of the next); then compound 3.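

Hydrogen in place of chloro on the aromatic carbon between two ring nitrogen atoms gives an 11-fold higher number from compound 2 to compound 3 (1.05 log units; beyond the scatter) in this assay and so marks this position as sensitive to the change, well beyond the scatter. Among the compounds shown here, compound 1 also carries hydrogen at this position and gives 2140 nM in this assay, so hydrogen here does not by itself set the value; the weak value is seen only with the chloromethyl placed as in compound 3. Nothing measured at hand accounts for the size of this step.

On these data alone, whether an amine, a methoxy group or a fluoro at this carbon would hold the value of compound 2 stays open. Also open, as far as these compounds go, is whether a chloro at this carbon would shift compound 1 as its removal shifts compound 2.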